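Ethoxy in Place of Ethyl: Expectation for Compound 3

The compounds below may be only part of what the source reports. "The series", "measured", "known", "first", "only" and "open" are said of these compounds alone.

Of the compounds shown here, two have numbers so far in a functional assay on A-375 cells (Homo sapiens) for antiproliferative activity, read by MTT assay, with a stated time of 24 h, tested at 0.05 ug/mL; a lower number here means a weaker effect, a higher number a stronger effect of the compound at the concentration tested. Compound 1 `CCOc1ccc2nc(C(=O)Nc3c(F)cc(-c4cccc(F)c4)cc3F)c(C)c(O)c2c1` gives 1.02%. For the measured compounds named here, compound 2 `CCc1ccc2nc(C(=O)Nc3c(F)cc(-c4cccc(F)c4)cc3F)c(C)c(C(=O)O)c2c1` gives 0.95%, the lower of the two numbers, with compound 1 a little above it and the gap within the scatter; the two differ in more than one place, so no single step is drawn between them, and all that can be said is that both sit at the bottom of the scale.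

Compound 3 `CCOc1ccc2nc(C(=O)Nc3c(F)cc(-c4cccc(F)c4)cc3F)c(C)c(C(=O)O)c2c1` is the next compound to be measured. Against compound 2 the change is ethoxy in place of ethyl on an aromatic carbon. Going by the values given here, both numbers measured so far lie close together, and compound 1, which already carries the ethoxy group, sits at 1.02%, so nothing beyond the scatter is expected in either direction. The expected step is a number 0.1 percentage points higher from compound 2 to compound 3 (within the scatter). Compound 3 is estimated at 1%, with a range from 0% to 8%.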

Compound 3, a percentage reported as inhibition, at one concentration (the size of the read-out at that concentration, not a potency): 1.96%
Estimate against measurement, compound 3: 1 percentage points below, within the range that was stated.
By their numbers in this assay, from the lowest: compounds 2, 1 and 3 (each within the scatter of the next).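

In this assay, the ethoxy-for-ethyl change on this aromatic carbon can now be read as a single step, a number 1 percentage points higher from compound 2 to compound 3 (within the scatter), so swapping these two groups at this position does not shift the read-out beyond the scatter. The second single step, carboxy in place of hydroxy on an aromatic carbon, gives a number 0.9 percentage points higher from compound 1 to compound 3 (within the scatter) and is also within the scatter, so neither change separates these compounds at the one concentration tested. No available information bears on why these numbers stay within the scatter.

As far as these compounds go, it remains open whether a longer chain such as propoxy or an amine on the ethoxy-bearing carbon would give a step beyond the scatter. The same question stands for a methyl ester or a primary amide in place of the carboxy group.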